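Aryl swap on an aromatic nitrogen: compound 3

The source may report more compounds than this note shows. Statements on the series, on what has been measured and on what is new or still open speak of the compounds shown alone.

Measured so far:
compound 1 `Cc1ccccc1-n1nncc1CN1C(=O)C2(C(C#N)=C(N)Oc3c(N)cc4nc5ccccc5nc4c32)c2ccccc21` — in an ADME assay on HUVEC cells (Homo sapiens) for antiproliferative activity, read by MTT assay, with a stated time of 48 h (a lower number here means a stronger inhibitor, a higher number a weaker inhibitor), compound 1 gives > 50000 nM, which is a limit of the assay and not a number.
compound 2 `N#CC1=C(N)Oc2c(N)cc3nc4ccccc4nc3c2C12C(=O)N(Cc1cnnn1-c1ccc([N+](=O)[O-])cc1[N+](=O)[O-])c1ccccc12` — in this assay compound 2 gives > 50000 nM, again a limit and not a number.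

Among the measured compounds shown here, compound 2 thus stands only at a limit in this assay, as does the one other value shown (the limit of > 50000 nM in this assay, at which 2 of the 2 values shown sit). For the measured compounds named here, the single step at this position, a step that the two limits leave unreadable from compound 1 to compound 2, is left unreadable by the two limits, so no size or direction can be taken from it.

Compound 3 `COc1cc(-n2nncc2CN2C(=O)C3(C(C#N)=C(N)Oc4c(N)cc5nc6ccccc6nc5c43)c3ccccc32)c(OC)cc1Cl` differs from compound 2 by 4-chloro-2,5-dimethoxyphenyl in place of 2,4-dinitrophenyl on an aromatic nitrogen. Going by the values given here, the one measured step that bears on this change, a step that the two limits leave unreadable from compound 1 to compound 2, gives no readable size, and both aryl groups so far tried on this nitrogen left the compound at the limit (the limit of > 50000 nM in this assay, at which 2 of the 2 values shown sit). The expectation for compound 3 is therefore no step beyond the scatter, a step that the limit leaves unreadable from compound 2 to compound 3, and most likely a limit once more. Compound 3 is estimated at 80000 nM, in the range 30000 nM to 300000 nM.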

Compound 3, half-maximal inhibitory concentration: > 50000 nM
Compound 3: a limit, no number; the forecaster's own chance of this, stated with the estimate: 85%; the middle value does not contradict the limit.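

Compound 3 is again a limit and not a number, so the steps among compound 1, compound 2 and compound 3 cannot be read in this assay: the limit of > 50000 nM in this assay, at which 3 of the 3 values shown sit.

The compounds shown leave open whether any aryl group on this aromatic nitrogen gives a readable value in this assay.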